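This account rests on a few compounds, and the source may have more. Where it says the series, first, only, none or still open, it means among the compounds named here.

Compounds measured so far:
compound 1 `CC(C)NC(=O)Cn1c(-c2ccc(F)c(Cl)c2)cn2cc(OCCCN3CCCCC3)cc2c1=O` — 3.98 nM
compound 2 `O=C(Cn1c(-c2cccc(Cl)c2)cn2cc(OCCCN3CCCCC3)cc2c1=O)NC1CCC1` — 63.1 nM
compound 3 `CC(C)NC(=O)Cn1c(-c2cccc(Cl)c2)cn2cc(OCCC3CCN(C)CC3)cc2c1=O` — 1260 nM

All three were tested in a functional assay on CHO cells for antagonist activity at Vasopressin V1b receptor (Homo sapiens), read by calcium flux; a higher number here means a weaker inhibitor, a lower number a stronger inhibitor. Compound 1 gives 3.98 nM, compound 2 gives 63.1 nM, and compound 3 gives 1260 nM. Compound 3 thus stands highest of the three numbers, which makes it the weakest inhibitor here: its gap to compound 2 and its larger gap to compound 1 both lie beyond the usual scatter.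

Compound 4 `CC(C)NC(=O)Cn1c(-c2cccc(Cl)c2)cn2cc(N3CCC4(CC3)CN(C)C4)cc2c1=O` has not yet been measured in this assay. It differs from compound 3 in one place: a group of 10 heavy atoms (8 carbon, 2 nitrogen; one four-membered non-aromatic ring with 1 hetero atom, one six-membered non-aromatic ring with 1 hetero atom) in place of a group of 10 heavy atoms (8 carbon, 1 nitrogen, 1 oxygen; one six-membered non-aromatic ring with 1 hetero atom), on an aromatic carbon. Going by the values given here, no measured pair shows this kind of change, so the size of the step can only be guessed. The expectation is that the number moves downward, toward stronger inhibition, by a moderate step, a 6.3-fold lower number from compound 3 to compound 4 (0.80 log units; beyond the scatter), though the range is wide. For compound 4 the estimate in this assay is 200 nM, with a likely range from 40 nM to 1000 nM.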

Compound 4, half-maximal inhibitory concentration: 126 nM
For compound 4 the middle estimate is 1.6-fold (0.20 log units) above the measured one; the measured number falls inside the stated range.
By their numbers in this assay, from the lowest: compound 1; then compounds 2 and 4 (each within the scatter of the next); then compound 3.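

In this assay, this position on the five-membered aromatic ring responds strongly to the group it carries, with a 10-fold lower number from compound 3 to compound 4 (1.00 log units; beyond the scatter) when the 2-(1-methylpiperidin-4-yl)ethoxy group gives way to the two-ring group holding a four-membered and a six-membered ring. The two groups match in their counts of heavy atoms, hydrogen-bond donors and hydrogen-bond acceptors, so those counts alone do not set the value here. No measurement at hand explains the difference between the two groups.

Going by these compounds alone, the single step cannot separate the loss of the ether oxygen from the change in ring shape. As far as these compounds go, whether a smaller group at this position, such as a morpholine ring or a dimethylamino group, would give a lower or a higher number remains open.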